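Changing the Amide-Side Pyridine of Compound 1

The compounds below may be only part of what the source reports. "The series", "measured", "known", "first", "only" and "open" are said of these compounds alone.

Measured compounds in a functional assay on HEK293 cells for negative allosteric modulation of metabotropic glutamate receptor 5 (Homo sapiens), read by FLIPR and calcium flux; a lower number here means a stronger inhibitor, a higher number a weaker inhibitor:
compound 1 `Cc1cccc(NC(=O)c2nn(C)c(-c3ccc(F)cc3)c2C)n1` gives 1.1 nM
compound 2 `Cc1cccc(NC(=O)c2nn(C)c(-c3ccc(F)cc3F)c2C)n1` gives 3.7 nM
compound 3 `Cc1cccc(NC(=O)c2nn(C)c(C3CCCCC3)c2C)n1` gives 25 nM

Compound 1 gives the lowest of the three numbers. The step of a 3.4-fold higher number from compound 1 to compound 2 (0.53 log units; beyond the scatter) is modest, the step of a 23-fold higher number from compound 1 to compound 3 (1.36 log units; beyond the scatter) is large, and between the other two the step of a 6.8-fold higher number from compound 2 to compound 3 (0.83 log units; beyond the scatter) is also modest, so every measured change on the ring carried by the shared core costs potency relative to compound 1.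

Compound 4 `Cc1c(C(=O)Nc2ccc(Cl)cn2)nn(C)c1-c1ccc(F)cc1` differs from compound 1 in another place: 5-chloropyridin-2-yl in place of 6-methylpyridin-2-yl on an amide-type nitrogen. Among the measured compounds shown here, none of the measured steps touches this amide-side pyridine; all three alter the ring on the core. The measured steps therefore do not bear on this change, and the data give no direct guide to its size or direction. With the core and its 4-fluorophenyl kept as in compound 1, compound 4 is expected to stay potent, with a step of a 2.7-fold higher number from compound 1 to compound 4 (0.44 log units; beyond the scatter) that may lie within the scatter or reach a modest loss. The estimate for compound 4 is 3 nM, ranging from 0.7 nM to 15 nM.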

Compound 4, half-maximal inhibitory concentration: 184 nM
Compound 4: the middle estimate sits 61-fold (1.79 log units) below what was measured; the whole stated range lies below it.
By their numbers in this assay, from the lowest: compound 1; then compound 2; then compound 3; then compound 4.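

In this assay, the amide-side pyridine turns out to be a sensitive position: a 170-fold higher number from compound 1 to compound 4 (2.22 log units; beyond the scatter) is larger than either step measured from compound 1 on the ring carried by the shared core. The two groups match in heavy-atom count, ring type, hydrogen-bond counts and charge, so none of these counted features separates them, yet the potency of compound 1 is not retained in compound 4. Nothing available here accounts for this loss.

Among the compounds shown here, the single change in compound 4 removes a methyl and adds a chlorine at once, so it remains open which of the two carries the loss. A plain pyridin-2-yl or a 6-chloropyridin-2-yl on the same amide nitrogen would be needed to separate them.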